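Tert-butyl on the phenyl of compound 1

A few compounds are considered here, and "the series" means these few. Any claim that something is new, unique, unknown or untested is made for them only; others in the source may bear on it.

Compound 1, with the structure `O=C1C2=C(C(=O)c3ncccc31)C1(CS2)NC(=O)N(c2ccccc2)C1=O`, is one of three compounds tested in a functional assay on SF-268 cells (Homo sapiens) for antiproliferative activity, read by MTT assay, with a stated time of 96 h; a lower number here means a stronger inhibitor, a higher number a weaker inhibitor. In this assay compound 1 gives 1700 nM, the lowest of the three numbers, but its distance to the others lies within the scatter. Compound 2, `Cc1ccc(N2NC(=O)NC3(CSC4=C3C(=O)c3ncccc3C4=O)C2=O)cc1`, gives 2100 nM, and compound 3, `O=C1NN(c2ccc(Cl)cc2)C(=O)C2(CSC3=C2C(=O)c2ncccc2C3=O)N1`, gives 2000 nM. For the measured compounds named here, compounds 2 and 3 carry their phenyl on a different ring arrangement than compound 1, and the one measured step between them, a 1.1-fold lower number from compound 2 to compound 3 (0.02 log units; within the scatter), swaps chloro for methyl on an aromatic carbon and lies within the scatter.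

Compound 4, `CC(C)(C)c1ccc(N2C(=O)NC3(CSC4=C3C(=O)c3ncccc3C4=O)C2=O)cc1`, differs from compound 1 by tert-butyl in place of hydrogen on an aromatic carbon. Going by the values given here, no measured step adds a group to a bare aromatic carbon of this phenyl, so the only guide is that changing one group for another on the phenyl of compound 2 and compound 3 moved the number very little. On that basis the step from compound 1 to compound 4 is expected to stay within the scatter, as no change at the digits printed from compound 1 to compound 4 (within the scatter). Compound 4 is therefore estimated at 1700 nM, with a likely range from 700 nM to 4200 nM.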

Compound 4, half-maximal inhibitory concentration: 500 nM
The estimate for compound 4 lay 3.4-fold (0.53 log units) above the measured number, and the stated range ends above it.
By their numbers in this assay, from the lowest: compound 4; then compounds 1, 3 and 2 (each within the scatter of the next).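

Placing tert-butyl on the phenyl, on an aromatic carbon para to a large group, gives a 3.4-fold lower number from compound 1 to compound 4 (0.53 log units; beyond the scatter) in this assay, a modest step but the only one here that lies beyond the scatter. This shows that the number can respond to what this phenyl carries, which the earlier step could not show: a 1.1-fold lower number from compound 2 to compound 3 (0.02 log units; within the scatter) stayed within the scatter, and it swapped one group for another on a different ring arrangement rather than adding a group to a bare aromatic carbon. Nothing measured here speaks to why the number falls with tert-butyl.

The compounds shown leave open whether a smaller branched group such as isopropyl, a longer chain such as n-butyl, or a very different group such as an amine or a carboxylic acid at this same place would also lower the number. They also leave open whether tert-butyl would give a similar step on the ring arrangement carried by compounds 2 and 3.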